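A few compounds are considered here, and "the series" means these few. Any claim that something is new, unique, unknown or untested is made for them only; others in the source may bear on it.

Working notes on the series: three compounds on the shared core have been read in a physicochemical assay for lipophilicity, read by HPLC, at pH 7.4; a higher number here means a more lipophilic compound, a lower number a more polar compound. Compound 1 `COCCOc1cc2oc(=O)n(CCC(=O)O)c2cc1Cl` gives 0.88, compound 2 `CCc1cc2oc(=O)n(CCC(=O)O)c2cc1Cl` gives 1.94, and compound 3 `O=C(O)CCn1c(=O)oc2cc(OCc3ccccc3)c(Cl)cc21` gives 2.71, the highest of the three numbers.

The next step leads to compound 4 `CC(C)Cc1cc2oc(=O)n(CCC(=O)O)c2cc1Cl`, with isobutyl in place of benzyloxy on an aromatic carbon. Within the data shown here, no measured compound carries isobutyl, so this step cannot be read directly from an earlier pair. The closest measured step is a number 0.77 log units higher from compound 2 to compound 3 (beyond the scatter), which is modest and beyond the scatter, and which also changes the group at this place. The steps of a number 1.06 log units higher from compound 1 to compound 2 (beyond the scatter) and a number 1.83 log units higher from compound 1 to compound 3 (beyond the scatter) are both large and beyond the scatter, so changes at this place have moved the number widely in this small set.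

Isobutyl is a carbon-only group, as is the ethyl of compound 2 at 1.94, but a longer one, so compound 4 is expected to land well above that value. The expected step is a number 0.11 log units lower from compound 3 to compound 4 (within the scatter), with no change beyond the scatter anticipated. For compound 4 the estimated value is 2.6, with an expected range from 2.2 to 3.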

Compound 4, distribution coefficient: 3.03
Estimate against measurement, compound 4: 0.43 log units below; measured number above the stated range.
By their numbers in this assay, from the lowest: compound 1; then compound 2; then compound 3; then compound 4.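

In this assay, among these compounds, isobutyl (4 heavy atoms, no ring) in place of benzyloxy (8 heavy atoms, one six-membered aromatic ring) gives a number 0.32 log units higher from compound 3 to compound 4 (beyond the scatter) and so the smaller group gives the higher number at this position, which the earlier compounds could not show. Isopropyl in place of methyl on the saturated chain carbon bound to an aromatic carbon gives a number 1.09 log units higher from compound 2 to compound 4 (beyond the scatter) and isobutyl in place of 2-methoxyethoxy gives a number 2.15 log units higher from compound 1 to compound 4 (beyond the scatter) so neither heavy atom count nor a carbon-only group alone orders the four compounds, with compound 4 going against the first reading and compound 2, which lies lower than compound 3, going against the second. No measurement at hand bears on why these steps take the sizes they do.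

The compounds shown leave open where a longer chain such as n-hexyl or a saturated ring such as cyclohexyl would fall relative to compound 4, and where an amine at this place would fall relative to compound 1. They also leave open whether the same order of groups would hold with another group in place of the chloro group.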